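Swapping the chloropyrimidine attachment point and expected solubility

The source may report more compounds than this note shows. Statements on the series, on what has been measured and on what is new or still open speak of the compounds shown alone.

Of the compounds shown here, three sharing one core have been measured in a physicochemical assay for solubility, read by HPLC, measured as octanol-water partition, at pH 7.4; on this read-out higher numbers stand for higher solubility and lower numbers for lower solubility. Compound 1, `Clc1ccc2c(NCCCNc3nccc(N4CCCC4)n3)ccnc2c1`, gives 1250 nM. Compound 2, `Clc1ccc2c(NCCCCNc3nccc(Cl)n3)ccnc2c1`, gives 3860 nM. Compound 3, `Clc1ccc2c(NCCNc3ccnc(Cl)n3)ccnc2c1`, gives 2090 nM. On these three numbers compound 3 stands second, but its gap to compound 1 and its gap to compound 2 are both within the usual scatter of this assay, so the three compounds cannot be told apart on solubility with any confidence.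

Compound 4, `Clc1ccc2c(NCCNc3nccc(Cl)n3)ccnc2c1`, has not yet been measured. It is built from the same atoms as compound 3, joined differently: 4-chloropyrimidin-2-yl in place of 2-chloropyrimidin-4-yl on an amine nitrogen. The chain, the core and the chlorine are all retained; only the point at which the chloropyrimidine ring is attached to the amine nitrogen moves.

Among the measured compounds no pair differs in a single place, so there is no measured step to lean on. With the atom count, ring count and hydrogen-bond acceptor count unchanged, the expected step from compound 3 to compound 4 in this assay is a 1.0-fold lower number from compound 3 to compound 4 (0.02 log units; within the scatter), which is no change beyond the scatter. Compound 4 is therefore estimated at 2000 nM, in a range from 900 nM to 4500 nM.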

Compound 4, solubility: 2850 nM
The estimate for compound 4 lay 1.4-fold (0.15 log units) below the measured number; low and high end bracket the measured number.
By their numbers in this assay, from the lowest: compounds 1, 3, 4 and 2 (each within the scatter of the next, the first and the last beyond it).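

For the compounds shown here, compound 3 and compound 4 are the first pair in this set that differ in one place only, so a single change can now be read on its own in this assay: putting 4-chloropyrimidin-2-yl in place of 2-chloropyrimidin-4-yl on an amine nitrogen gives a 1.4-fold higher number from compound 3 to compound 4 (0.13 log units; within the scatter), a step that stays inside the normal spread of repeated measurements. Going by these compounds alone, at this position, on a nitrogen whose other neighbour is a saturated chain carbon, the two ways of attaching the chloropyrimidine ring therefore cannot be told apart on this read-out, which the earlier compounds, each differing from the others in more than one place, could not show. Nothing measured here offers an explanation for this result, so it stands as an observation on one pair.

From the compounds shown here alone, a single pair sets no rule, so it remains open whether the attachment point would matter as little on a different chain length. Going by these compounds, it also remains open whether the same holds when a morpholine ring or a carboxylic acid takes the place of the chlorine.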